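This account rests on a few compounds, and the source may have more. Where it says the series, first, only, none or still open, it means among the compounds named here.

Working notes on the series. In a functional assay on NCI-H23 cells (Homo sapiens) for cytotoxicity, read by sulforhodamine B assay, with a stated time of 48 h, tested at 0.01 uM (a higher number here means a weaker effect of the compound at the concentration tested, a lower number a stronger effect), compound 2 `COc1cc(-c2cc(/C=C/C(=O)c3ccc(Cl)c(Cl)c3)[nH]n2)cc(OC)c1OC` gives 95%. Among the measured compounds shown here, compound 1 `COc1ccc(-c2cc(/C=C/C(=O)c3ccc(N)cc3)[nH]n2)cc1`, the only other compound with a number, gives 92% in this assay; the two values lie within the usual scatter of each other, so compound 2 sits at the same level as compound 1.

Compound 3 `COc1cc(-c2cc(/C=C/C(=O)c3ccc(F)c(F)c3)[nH]n2)cc(OC)c1OC` has not been measured. It differs from compound 2 by 3,4-difluorophenyl in place of 3,4-dichlorophenyl on a carbonyl carbon.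

For the measured compounds named here, no step between measured compounds exists in this set, so nothing shows how such a change moves the number; the expectation is no step from compound 2 to compound 3 beyond the scatter, with a number 1 percentage points lower from compound 2 to compound 3 (within the scatter) as the estimated change. Compound 3 is expected to give 94% in this assay, within a range from 84% to 102%.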

Compound 3, a percentage reported as activity, at one concentration (the size of the read-out at that concentration, not a potency): 95%
The estimate for compound 3 lay 1 percentage points below the measured number; the range from low to high includes it.
By their numbers in this assay, from the lowest: compounds 1, 2 and 3 (each within the scatter of the next).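

Replacing 3,4-dichlorophenyl with 3,4-difluorophenyl on a carbonyl carbon gives no change at the digits printed from compound 2 to compound 3 (within the scatter) in this assay. Among the compounds shown here, this is the first step that can be read at this position, and at this single concentration the read-out does not separate the two halogenated groups. No measured finding bears on this result. Still open, as far as these compounds go, is whether a different group at this place, such as a carboxylic acid or a longer alkyl chain, would move the number beyond the scatter.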